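Cycloheptyl in place of 2,4-difluorophenyl

The source may report more compounds than this note shows. Statements on the series, on what has been measured and on what is new or still open speak of the compounds shown alone.

Measured in an ADME assay on MT2 cells (Homo sapiens) for cytotoxicity, read by XTT assay, with a stated time of 4 days; on this read-out lower numbers stand for higher toxicity in this test and higher numbers for lower toxicity in this test:
Compound 1 `Cc1ccc(NC(=O)C(=O)NC(c2nc(C)c(CCO)s2)C2CCCCN2)cc1F`: 85000 nM
Compound 2 `Cc1nc(C(NC(=O)C(=O)Nc2ccc(F)cc2F)C2CCCCN2)sc1CCO`: > 105000 nM

The reading for compound 2, > 105000 nM, is a limit and not a number. Compound 3 `Cc1nc(C(NC(=O)C(=O)NC2CCCCCC2)C2CCCCN2)sc1CCO` differs from it in one place: cycloheptyl in place of 2,4-difluorophenyl on an amide-type nitrogen. Among the measured compounds shown here, the only measured step shows an at least 1.2-fold higher number from compound 1 to compound 2 (0.09 log units; that floor lies within the scatter). For the measured compounds named here, that step exchanges one substituted phenyl group for another, and no measured step covers cycloheptyl, so the expectation is loose. No large change is expected in this assay, perhaps a small move towards a lower number. The expected step is an at least 1.3-fold lower number from compound 2 to compound 3 (0.11 log units; that floor lies within the scatter). For compound 3 the estimate is 80000 nM, with an expected range of 30000 nM to 170000 nM.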

Compound 3, half-maximal cytotoxic concentration: 60000 nM
For compound 3 the middle estimate is 1.3-fold (0.12 log units) above the measured one; measured number inside the range.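

With cycloheptyl, a non-aromatic carbon ring takes the place of a substituted phenyl on the amide-type nitrogen, and this assay gives a reading close to that of compound 1, with a 1.4-fold lower number from compound 1 to compound 3 (0.15 log units; within the scatter). Against the difluorophenyl analogue there is an at least 1.7-fold lower number from compound 2 to compound 3 (0.24 log units; that floor lies within the scatter). That step is only a floor, as the reading for compound 2 is a limit and not a number: the limit of > 105000 nM in this assay, at which 1 of the 3 values shown sits.

Going by these compounds, what remains open is how a cycloheptyl ring carrying an amine or a carboxylic acid would read here. Also open, on these data alone, is whether any group on this nitrogen gives a step beyond the scatter.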